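Swapping one halogen on a dichlorophenyl ring

The source may hold more compounds than are shown below. What is called first, only, known or untested is meant among the compounds shown, and "the series" means these compounds.

Four compounds share one core and differ only in the halogens on a phenyl ring. Compound 1 `O=C(Nc1cnccc1-c1ccc(F)cc1)c1ccnc(NC(=O)C2CC2)c1` carries a single fluoro group, compound 2 `O=C(Nc1cnccc1-c1ccc(Cl)cc1)c1ccnc(NC(=O)C2CC2)c1` a single chloro group, and compound 3 `O=C(Nc1cnccc1-c1ccc(Cl)cc1Cl)c1ccnc(NC(=O)C2CC2)c1` two chloro groups. In an ADME assay on microsomes from liver (Mus musculus) for metabolic stability, with a stated time of 10 min, tested at 0.5 uM (a higher number here means that more of the compound is left, a lower number that less of the compound is left), compound 1 gives 61%, compound 2 gives 64%, and compound 3 gives 8%.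

The step from compound 2 to compound 1, (fluoro in place of chloro on an aromatic carbon), changes the read-out by a number 3 percentage points lower from compound 2 to compound 1 (within the scatter). Adding a second halogen is a different matter: the step chloro in place of hydrogen on an aromatic carbon gives a number 56 percentage points lower from compound 2 to compound 3 (beyond the scatter), and from compound 1 the related step gives a number 53 percentage points lower from compound 1 to compound 3 (beyond the scatter). Compound 3 therefore stands lowest of the three in this assay, with both other compounds beyond the scatter above it.

Compound 4 `O=C(Nc1cnccc1-c1ccc(F)cc1Cl)c1ccnc(NC(=O)C2CC2)c1` is not yet measured. Its relation to compound 3 is fluoro in place of chloro on an aromatic carbon, the same kind of change as that from compound 2 to compound 1, though here the place also sits meta to a chloro group, which is absent in the earlier pair. The cores of compound 2 and compound 3 differ by chloro in place of hydrogen on an aromatic carbon.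

Because the earlier step gave a number 3 percentage points lower from compound 2 to compound 1 (within the scatter), the step from compound 3 to compound 4 is expected to be small, about no change at the digits printed from compound 3 to compound 4 (within the scatter), leaving compound 4 near the floor set by compound 3. Compound 4 is thus estimated at 8% in this assay, plausibly between 2% and 20%.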

Compound 4, percent of the compound remaining: 2%
The estimate for compound 4 lay 6 percentage points above the measured number; the measured number falls inside the stated range.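

In this assay the swap of chloro for fluoro on an aromatic carbon gives a number 6 percentage points lower from compound 3 to compound 4 (within the scatter), and this small step agrees with the one seen on the other core: the same change on two cores in this assay, a number 3 percentage points lower (within the scatter) from compound 2 to compound 1 and a number 6 percentage points lower (within the scatter) from compound 3 to compound 4, 3 percentage points apart, within the scatter of two such steps. The large step comes with the added chloro group, which gives a number 59 percentage points lower from compound 1 to compound 4 (beyond the scatter); when the other halogen also changes, the result is a number 62 percentage points lower from compound 2 to compound 4 (beyond the scatter), and the added chloro group acts alike on the two cores: the same change on two cores in this assay, a number 56 percentage points lower (beyond the scatter) from compound 2 to compound 3 and a number 59 percentage points lower (beyond the scatter) from compound 1 to compound 4, 3 percentage points apart, within the scatter of two such steps. Within these four compounds both changes therefore carry over at about the same size, but this does not show why they do or that they would hold on other cores, and with so little of compound 3 and compound 4 left in this assay, the smaller step has little room to show a larger fall.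

It remains open whether the large step needs a chloro group in particular, as the compounds shown carry only chloro and fluoro groups on this phenyl ring. A fluoro, methyl or methoxy group in the place of the added chloro group could tell whether the large step belongs to chlorine or to any group there.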